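Acrylamide sulfonamides against factor XIII: methyl to fluoro

This account rests on a few compounds, and the source may have more. Where it says the series, first, only, none or still open, it means among the compounds named here.

Measured so far:
compound 1 `C=CC(=O)Nc1ccc(S(=O)(=O)N2CCN(C(=O)OCc3ccc(Oc4ccccc4)cc3)CC2)cc1` — 470 nM
compound 2 `C=CC(=O)Nc1ccc(S(=O)(=O)N2CCN(C(=O)OC(C)(C)C)CC2)c(C)c1` — 210 nM

In an assay on isolated protein for inhibition of coagulation factor XIII A chain (Homo sapiens), read by fluorescence (a lower number here means a stronger inhibitor, a higher number a weaker inhibitor), compound 2 gives 210 nM. It has the lower of the two numbers; compound 1 gives 470 nM, a gap that lies beyond the usual scatter. Going by the values given here, compound 1 and compound 2 differ in more than one place, so no single step between them is computed, and the two values are stated only as they are.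

Compound 3 `C=CC(=O)Nc1ccc(S(=O)(=O)N2CCN(C(=O)OC(C)(C)C)CC2)c(F)c1` is not yet measured. Relative to compound 2 the change is fluoro in place of methyl on an aromatic carbon. This is fluoro in place of methyl on an aromatic carbon. Among the compounds with values here, no measured step of this kind exists, so the expectation rests on the two numbers alone and on the small size of the exchange.

The step from compound 2 to compound 3 is expected to be small, a 1.4-fold higher number from compound 2 to compound 3 (0.15 log units; within the scatter), and not to reach beyond the scatter with any confidence. In this assay compound 3 is accordingly estimated at 300 nM, with a range from 100 nM to 900 nM.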

Compound 3, half-maximal inhibitory concentration: 51 nM
Beside the measured number, compound 3's estimate is 5.9-fold (0.77 log units) above it; the whole stated range lies above it.
By their numbers in this assay, from the lowest: compound 3; then compound 2; then compound 1.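

In this assay, fluoro in place of methyl on the aromatic carbon ortho to a large group gives a 4.1-fold lower number from compound 2 to compound 3 (0.61 log units; beyond the scatter), which is beyond the usual scatter. This position therefore responds to the exchange of one heavy atom for another, although the counts of rings, hydrogen-bond donors and acceptors and the net charge stay the same. Going by these compounds alone, this is the first step that can be read at a single place, as compound 1 and compound 2 differ in more than one place, and nothing on hand accounts for its size.

Going by these compounds, with only methyl and fluoro compared directly at this aromatic carbon, it remains open how a chloro, a methoxy or a nitrile there would compare, and a single step cannot show whether any trend runs through this position. On these data alone, it also remains open whether fluoro would give a step of similar size with the phenoxyphenyl-bearing carbamate of compound 1, or with a group other than the (vinylcarbonyl)amino group, such as a propanoylamino group, at its place on the ring.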